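This account rests on a few compounds, and the source may have more. Where it says the series, first, only, none or still open, it means among the compounds named here.

In an assay on PC-12 cells for displacement of a labelled ligand from Nischarin (Rattus norvegicus) (a lower number here means a stronger inhibitor, a higher number a weaker inhibitor), compound 2 `CC(Cc1ccccc1-c1ccccc1)C1=NCCN1` gives 155 nM. Compound 1 `C[C@H](Cc1ccccc1-c1ccccc1)C1=NCCN1`, the same molecule drawn with a defined configuration at one chain carbon, gives 2240 nM, so a 14-fold lower number from compound 1 to compound 2 (1.16 log units; beyond the scatter); the pair differs only in the way that stereocentre is drawn (the fact that one of compounds 1 and 2 is drawn with a defined configuration and the other without, at the place where they differ). Compound 3 `CC(Cc1ccccc1-c1cccnc1)C1=NCCN1` carries pyridin-3-yl where compound 2 carries phenyl. In this assay compound 3 gives > 1000 nM, which is a limit of the assay and not a number (the limit of > 1000 nM in this assay, at which 1 of the 3 values shown sits). That step, an at least 6.4-fold higher number from compound 2 to compound 3 (0.80 log units; beyond the scatter), places compound 3 at the weak end of what has been measured, with no exact figure.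

Compound 4 `CC(Cc1ccccc1Cl)C1=NCCN1` has not yet been measured. It differs from compound 3 by chloro in place of pyridin-3-yl on an aromatic carbon. Going by the values given here, only the step from compound 2 to compound 3 bears on this change, and it shows that swapping the phenyl for pyridin-3-yl cost binding. Removing the ring altogether in favour of chloro is a different kind of change, so the direction is open, though a return toward the phenyl compound's level is possible. Compound 4 is therefore estimated at 600 nM, within a range from 60 nM to 6000 nM. Compared with the limit of compound 3, this would be expected to mean an at least 1.6-fold lower number from compound 3 to compound 4 (0.22 log units; that floor lies within the scatter).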

Compound 4, inhibition constant: 195 nM
Estimate against measurement, compound 4: 3.1-fold (0.49 log units) above, and the stated range covers the measured number.
By their numbers in this assay, from the lowest: compounds 2 and 4 (each within the scatter of the next); then compound 1.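

In this assay, the new result shows that this aromatic carbon does not need a second ring to keep binding at the level of the phenyl compound, as a single chloro of 1 heavy atom serves as well as the six-atom phenyl ring, with a 1.3-fold higher number from compound 2 to compound 4 (0.10 log units; within the scatter). Replacing pyridin-3-yl with chloro gives an at least 5.1-fold lower number from compound 3 to compound 4 (0.70 log units; beyond the scatter), so among the three groups seen at this position, pyridin-3-yl alone stands apart, and the loss seen earlier cannot be read as a general penalty for changing the phenyl ring. Compound 3 stands at a limit of the assay and not at a number, so that step gives only a minimum size: the limit of > 1000 nM in this assay, at which 1 of the 4 values shown sits.

The compounds shown leave open whether other small groups at this position, such as fluoro, methyl or methoxy, would bind like chloro, and whether a plain hydrogen there would do the same. They also leave open how the drawn configuration at the chain carbon plays out for the chloro series, as compound 4 is drawn without one, and whether pyridin-2-yl or pyridin-4-yl would fare like pyridin-3-yl.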